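The source may report more compounds than this note shows. Statements on the series, on what has been measured and on what is new or still open speak of the compounds shown alone.

Compound 2 `COCC#Cc1cc(C(O)(C(F)(F)F)C(F)(F)F)cnc1N1CCN(S(=O)(=O)c2ccc(N)nc2)CC1` stands highest of the three measured compounds in an ADME assay (liver) for metabolic stability, with Liver microsome (Rattus norvegicus) as the target, using microsomes and NADPH, with a stated time of 30 min, tested at 1 uM (a lower number here means slower removal, a higher number faster removal of the compound), giving 399 mL.min-1.g-1. Compound 1 `Nc1ccc(S(=O)(=O)N2CCN(c3ncc(C(O)(C(F)(F)F)C(F)(F)F)cc3C#CCO)CC2)cn1` gives 65 mL.min-1.g-1 and compound 3 `CC(C)(O)C#Cc1cc(C(O)(C(F)(F)F)C(F)(F)F)cnc1N1CCN(S(=O)(=O)c2ccc(N)nc2)CC1` gives 16 mL.min-1.g-1. The steps are a 6.1-fold higher number from compound 1 to compound 2 (0.79 log units; beyond the scatter), a 4.1-fold lower number from compound 1 to compound 3 (0.61 log units; beyond the scatter) and a 25-fold lower number from compound 2 to compound 3 (1.40 log units; beyond the scatter). Compound 4 `CC(C)n1cc(-c2cc(C(O)(C(F)(F)F)C(F)(F)F)cnc2N2CCN(S(=O)(=O)c3ccc(N)nc3)CC2)cn1` differs from compound 2 by 1-isopropyl-1H-pyrazol-4-yl in place of 3-methoxyprop-1-yn-1-yl on an aromatic carbon. Within the data shown here, each measured step alters only the end of the triple-bonded chain, and no measured compound carries the pyrazole, so they bear on the change only in that the methoxymethyl group, whose arrival gave a 6.1-fold higher number from compound 1 to compound 2 (0.79 log units; beyond the scatter), departs. Compound 4 is therefore expected to show a modest downward step of a 2.7-fold lower number from compound 2 to compound 4 (0.42 log units; beyond the scatter) in this assay, with wide uncertainty. Compound 4 is estimated at 150 mL.min-1.g-1, within a range from 50 mL.min-1.g-1 to 450 mL.min-1.g-1.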

Compound 4, intrinsic clearance in microsomes: 198 mL.min-1.g-1
Estimate against measurement, compound 4: 1.3-fold (0.12 log units) below; the range from low to high includes it.
By their numbers in this assay, from the lowest: compound 3; then compound 1; then compounds 4 and 2 (each within the scatter of the next).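

In this assay the 1-isopropyl-1H-pyrazol-4-yl group, a five-membered aromatic ring with no triple bond, takes this aromatic carbon with no change beyond the scatter against the 3-methoxyprop-1-yn-1-yl group (a 2.0-fold lower number from compound 2 to compound 4 (0.30 log units; within the scatter)). The two chains ending in a hydroxyl group stand apart from it (a 12-fold higher number from compound 3 to compound 4 (1.09 log units; beyond the scatter) and a 3.0-fold higher number from compound 1 to compound 4 (0.48 log units; beyond the scatter)). Nothing given here explains these steps. On these data alone, whether a hydroxyl group on the isopropyl group would move compound 4 toward compound 3 remains open, as does the effect of a methyl group in place of that isopropyl group.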